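The compounds below may be only part of what the source reports. "The series", "measured", "known", "first", "only" and "open" are said of these compounds alone.

Of the compounds shown here, three built on a shared core have been tested in a functional assay on T47D cells (Homo sapiens) for activation; on this read-out lower numbers stand for an effect already at smaller amounts and higher numbers for an effect only at larger amounts of compound. Compound 1 `COc1ccc2c(c1)OC(N)=C(C#N)C2c1cccc([N+](=O)[O-])c1` gives 88900000 nM. Compound 3 `COc1cccc(C2C(C#N)=C(N)Oc3cc(OC)ccc32)c1` gives 52000000 nM, and the step of a 1.7-fold lower number from compound 1 to compound 3 (0.23 log units; within the scatter) lies within the scatter. Compound 2 `N#CC1=C(N)Oc2c(ccc(N)c2N)C1c1cccc(C#N)c1` gives 390000000 nM, the highest of the three numbers and beyond the scatter from both compound 1 and compound 3. Compound 4 `N#CC1=C(N)Oc2c(ccc(N)c2N)C1c1cccc([N+](=O)[O-])c1` differs from compound 2 in one place: nitro in place of cyano on an aromatic carbon. Among the compounds with values here, no measured step exchanges these two groups directly; the only measured step that involves a nitro group, from compound 1 to compound 3, stayed within the scatter. Little movement beyond the scatter is therefore expected. The estimate for compound 4 is 250000000 nM, with a range from 80000000 nM to 800000000 nM. The expected step is a 1.6-fold lower number from compound 2 to compound 4 (0.19 log units; within the scatter).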

Compound 4, half-maximal effective concentration: 390000000 nM
Estimate against measurement, compound 4: 1.6-fold (0.19 log units) below; measured number inside the range.
By their numbers in this assay, from the lowest: compounds 3 and 1 (each within the scatter of the next); then compounds 2 and 4 (each within the scatter of the next).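

In this assay, within the data shown here, the exchange of cyano for nitro on this aromatic carbon gives no change at the digits printed from compound 2 to compound 4 (within the scatter) and so puts the two groups side by side for the first time. On the core of compound 2, the number therefore does not separate nitro from cyano at this position. Nothing measured here accounts for this result. Going by these compounds, whether an amine or a carboxylic acid on the same aromatic carbon would shift the number remains open. So does whether nitro and cyano would also match on the core of compound 1.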